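The compounds below may be only part of what the source reports. "The series", "measured", "known", "first", "only" and "open" are said of these compounds alone.

The compounds share one core. Compound 1 `Cc1cc(Nc2cc(-c3ccccc3)[nH]n2)n2nc(SCc3c(Cl)cccc3Cl)nc2n1` is measured in an ADME assay on GES1 cells (Homo sapiens) for inhibition, read by MTT assay, with a stated time of 72 h (on this read-out lower numbers stand for stronger inhibition and higher numbers for weaker inhibition), where compound 1 gives 39600 nM. Compound 2 `Cc1cc(Nc2ccn(Cc3nc(C)c4ccccc4n3)n2)n2nc(SCc3ccc(Br)cc3)nc2n1` gives 36800 nM in this assay. Compound 3 `Cc1ccc(Cn2ccc(Nc3cc(C)nc4nc(SCc5ccc(Br)cc5)nn34)n2)cc1` gives only a limit in this assay, namely > 50000 nM. Of the two numbers shown, compound 1 has the highest, and compound 2 sits within the usual scatter of it. Among the measured compounds shown here, the one measured step, an at least 1.3-fold higher number from compound 2 to compound 3 (0.13 log units; that floor lies within the scatter), changes a group on a saturated chain carbon bound to an aromatic nitrogen, not the one bound to a sulfur, so it does not speak to the change at hand. Compound 4 `CCCSc1nc2nc(C)cc(Nc3cc(-c4ccccc4)[nH]n3)n2n1` differs from compound 1 on the sulfur side: ethyl in place of 2,6-dichlorophenyl on a saturated chain carbon bound to a sulfur. For the measured compounds named here, no measured step covers such a change, so there is no basis for expecting a shift in this assay beyond the scatter in either direction. Compound 4 is therefore estimated at 45000 nM, with a range from 20000 nM to 100000 nM, and a fair chance that this assay returns only a limit. The expected step is a 1.1-fold higher number from compound 1 to compound 4 (0.06 log units; within the scatter).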

Compound 4, half-maximal inhibitory concentration: > 50000 nM
Compound 4: only a limit was reported; the forecaster's own chance of this, stated with the estimate: 45%; at least 1.1-fold (0.04 log units) between middle value and limit.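

Among the compounds shown here, this is the first reading of a change on the sulfur side of the shared core, on a saturated chain carbon bound to a sulfur. Replacing 2,6-dichlorophenyl with ethyl there gives an at least 1.2-fold higher number from compound 1 to compound 4 (0.10 log units; that floor lies within the scatter) in this assay, so the change shows no shift beyond the scatter, yet it does not rule out a larger one. The step is only a floor, and the true distance stays unread because compound 4 reaches the end of the readable range: the limit of > 50000 nM in this assay, at which 2 of the 4 values shown sit.

The compounds shown leave open how far past this limit compound 4 lies, and whether the same change reads alike with the other groups carried by compound 2 and compound 3. They also leave open whether a longer chain, an amine or a carboxylic acid on that saturated chain carbon would give a number rather than a limit.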